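Working notes: the step from compound 3 to compound 4

The source may report more compounds than this note shows. Statements on the series, on what has been measured and on what is new or still open speak of the compounds shown alone.

Measured in a functional assay on MCF7 cells (Homo sapiens) for antiproliferative activity, read by MTT assay, with stated times of 24 h and 72 h; a higher number here means a weaker inhibitor, a lower number a stronger inhibitor:
- compound 1 `COc1cc(N2C(=O)[C@@H](Oc3ccccc3)[C@H]2c2ccc(N(C)C)cc2)cc(OC)c1OC`: 31000 nM
- compound 2 `COc1cc(N2C(=O)[C@@H](Oc3ccccc3)[C@H]2c2ccc([N+](=O)[O-])cc2)cc(OC)c1OC`: 63000 nM
- compound 3 `COc1cc(N2C(=O)[C@@H](Oc3ccccc3)[C@H]2c2ccc(SC)cc2)cc(OC)c1OC`: 7700 nM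

Compound 3 has the lowest number of the three. Compound 4 `COc1cc(N2C(=O)[C@@H](Oc3ccccc3)[C@H]2c2cccc(O)c2)cc(OC)c1OC` carries 3-hydroxyphenyl in place of 4-(methylsulfanyl)phenyl on a saturated ring carbon. Within the data shown here, no measured compound carries a hydroxy group, so the evidence is indirect. Both measured replacements of methylsulfanyl go with higher numbers, as a 4.0-fold lower number from compound 1 to compound 3 (0.60 log units; beyond the scatter) and an 8.2-fold lower number from compound 2 to compound 3 (0.91 log units; beyond the scatter) show. A modest rise in this assay is therefore expected. The expected step is a 1.8-fold higher number from compound 3 to compound 4 (0.26 log units; within the scatter). Compound 4 is estimated at 14000 nM, with an expected range of 3500 nM to 55000 nM.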

Compound 4, half-maximal inhibitory concentration: 54000 nM
Compound 4: middle estimate off by 3.9-fold (0.59 log units), on the low side; the range from low to high includes it.
By their numbers in this assay, from the lowest: compound 3; then compounds 1, 4 and 2 (each within the scatter of the next, the first and the last beyond it).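

In this assay, compound 4 loses the advantage held by 4-(methylsulfanyl)phenyl (a 7.0-fold higher number from compound 3 to compound 4 (0.85 log units; beyond the scatter)). It also falls within the scatter of both the nitro compound (a 1.2-fold lower number from compound 2 to compound 4 (0.07 log units; within the scatter)) and the dimethylamino compound (a 1.7-fold higher number from compound 1 to compound 4 (0.24 log units; within the scatter)), so a hydroxy group on this ring does not recover the activity of compound 3.

This change alters both the group and its place on the ring, and the compounds shown cannot separate the two. 4-Hydroxyphenyl and 3-(methylsulfanyl)phenyl remain open, as does 4-methoxyphenyl. No supporting measurement explains the result.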